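A few compounds are considered here, and "the series" means these few. Any claim that something is new, unique, unknown or untested is made for them only; others in the source may bear on it.

Going by the values given here, in a functional assay on HOP-92 cells (Homo sapiens) for inhibition, read by sulforhodamine B assay, with a stated time of 48 h (a higher number here means a weaker inhibitor of growth, a lower number a stronger inhibitor of growth), compound 1 (`O=C(Cc1csc2nc(-c3ccc(Br)cc3)cn12)N/N=C/c1ccccc1`) gives 37200 nM and compound 2 (`O=C(Cc1csc2nc(-c3ccc(Br)cc3)cn12)N/N=C/c1ccccc1O`) gives 14500 nM, the lower of the two numbers so far. Among the compounds with values here, the only measured step is a 2.6-fold lower number from compound 1 to compound 2 (0.41 log units; beyond the scatter), for hydroxy in place of hydrogen on an aromatic carbon. Compound 3 (`O=C(Cc1csc2nc(-c3ccc(Br)cc3)cn12)N/N=C/c1ccc(O)cc1`) is the next case: 4-hydroxyphenyl in place of 2-hydroxyphenyl on a carbon with a double bond to nitrogen. In words, 4-hydroxyphenyl stands in place of 2-hydroxyphenyl on a carbon with a double bond to nitrogen. Within the data shown here, no measured step covers this kind of change, so the single step of a 2.6-fold lower number from compound 1 to compound 2 (0.41 log units; beyond the scatter) serves only as a guide to size. The expected change in this assay is small, toward a higher number, and may stay within the scatter. The estimated step is a 1.5-fold higher number from compound 2 to compound 3 (0.18 log units; within the scatter). For compound 3 the estimated value is 22000 nM, with an expected range of 9000 nM to 48000 nM.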

Compound 3, concentration for total growth inhibition: 69200 nM
Compound 3: middle estimate off by 3.1-fold (0.50 log units), on the low side, and the stated range ends below it.
By their numbers in this assay, from the lowest: compound 2; then compounds 1 and 3 (each within the scatter of the next).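

In this assay, the place of the hydroxy on the phenyl ring matters: 4-hydroxyphenyl in place of 2-hydroxyphenyl gives a 4.8-fold higher number from compound 2 to compound 3 (0.68 log units; beyond the scatter), a step larger than the earlier gain of a 2.6-fold lower number from compound 1 to compound 2 (0.41 log units; beyond the scatter) and opposite in direction. That gain therefore does not extend to every hydroxy in place of hydrogen, since adding the hydroxy as 4-hydroxyphenyl gives a 1.9-fold higher number from compound 1 to compound 3 (0.27 log units; within the scatter), and only 2-hydroxyphenyl stands apart from the unsubstituted phenyl among these three compounds. No supporting data bear on why the two hydroxyphenyl groups differ.

On these data alone, it remains open whether the result with 2-hydroxyphenyl depends on the hydroxy itself or would also hold for a methoxy or an amine in its place. As far as these compounds go, the effect of replacing the bromine on the other aryl group of the shared core also remains open.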